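This account rests on a few compounds, and the source may have more. Where it says the series, first, only, none or still open, it means among the compounds named here.

Measured in a functional assay for inhibition, with Rattus norvegicus as the target; on this read-out higher numbers stand for weaker inhibition and lower numbers for stronger inhibition:
- compound 1 `CCCCc1c(CC)c(OC(C)=O)c2ccccc2c1OC`: 1130 nM
- compound 2 `CCc1c(CC)c(OC(C)=O)c2ccccc2c1OC`: 400 nM
- compound 3 `CCc1c(CC)c(OC(C)=O)c2cc(OC)ccc2c1OC`: 690 nM

Compound 2 stands at the low end of these numbers, though only compound 1 is separated from it beyond the scatter. Compound 3 remains within the scatter of it. The unmeasured compound 4 `CCCCc1ccc2c(OC(C)=O)c(CC)c(CC)c(OC)c2c1` departs from compound 2 by butyl in place of hydrogen on an aromatic carbon.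

Among the compounds with values here, no measured compound carries this exact change, so two steps serve as indirect guides. The closer in place is the methoxy change, a 1.7-fold higher number from compound 2 to compound 3 (0.24 log units; within the scatter), which stays within the scatter. The other is the change on the saturated chain, a 2.8-fold lower number from compound 1 to compound 2 (0.45 log units; beyond the scatter), where the compound with the extra ethyl has the higher number. Together they suggest a modest rise in this assay, of similar size to these two steps, with little certainty about its direction.

The expected step is a 2.1-fold higher number from compound 2 to compound 4 (0.33 log units; beyond the scatter). For compound 4 the estimated value is 850 nM, with an expected range of 320 nM to 2200 nM.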

Compound 4, half-maximal inhibitory concentration: 940 nM
Compound 4: the middle estimate sits 1.1-fold (0.04 log units) below what was measured; measured number inside the range.
By their numbers in this assay, from the lowest: compounds 2, 3, 4 and 1 (each within the scatter of the next, the first and the last beyond it).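

Within the data shown here, the earlier compounds all carry hydrogen on this aromatic carbon, so compound 4 gives the first reading of a substituent there. In this assay, butyl in place of hydrogen gives a 2.4-fold higher number from compound 2 to compound 4 (0.37 log units; beyond the scatter), a modest loss beyond the scatter. Inhibition nevertheless persists with this chain in place, as compound 4 still gives a finite 940 nM. Nothing available explains the rise in the number.

The compounds shown leave open whether the effect depends on chain length, since a single step cannot show how a methyl or a hexyl chain on this carbon would read. They also leave open whether a group of another kind, such as an amine or a carboxylic acid, would be tolerated on this carbon.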